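Piperidine isomer swap on the shared core

The source may hold more compounds than are shown below. What is called first, only, known or untested is meant among the compounds shown, and "the series" means these compounds.

Working notes on four compounds built on one shared core: compound 1 `Cc1cc(-c2cc(N3C[C@H](O)[C@@H](O)C3)ccc2O)nc(N)n1`, compound 2 `Nc1nc(NC2CCCCC2)cc(-c2cc(N3C[C@H](O)[C@@H](O)C3)ccc2O)n1`, compound 3 `Nc1nc(-c2cc(N3C[C@H](O)[C@@H](O)C3)ccc2O)cc(C2CCNCC2)n1` and compound 4 `Nc1nc(-c2cc(N3C[C@H](O)[C@@H](O)C3)ccc2O)cc(C2CCCNC2)n1`. In a functional assay on A549 cells (Homo sapiens) for cytotoxicity, with a stated time of 48 h (on this read-out lower numbers stand for stronger inhibition of growth and higher numbers for weaker inhibition of growth), compound 1 gives 2000 nM. In this assay compound 2 gives 1500 nM. In this assay compound 3 stands as "not determined" (no result reported), with no reported result, so it offers no number to step from.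

The change from compound 3 to compound 4 is piperidin-3-yl in place of piperidin-4-yl on an aromatic carbon, with the same atoms joined differently.

Among the measured compounds shown here, the only measured step is cyclohexylamino in place of methyl on an aromatic carbon, a 1.3-fold lower number from compound 1 to compound 2 (0.12 log units; within the scatter). It involves neither piperidinyl group, so it bears only indirectly, as a sign that one large change on an aromatic carbon left this assay within the scatter. No step beyond the scatter is expected, and no direction can be given. The estimate therefore rests on compound 1 and compound 2, with a wide range.

For compound 4 the expected value is 1700 nM, with an estimated range of 600 nM to 5000 nM.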

Compound 4, concentration for 50% growth inhibition: > 10000 nM
Compound 4: a limit, no number; the forecaster's own chance of this, stated with the estimate: 10%; middle value at least 5.8-fold (0.76 log units) from the limit.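

In this assay compound 4 stands as a limit and not as a number: the limit of > 10000 nM in this assay, at which 1 of the 4 values shown sits. The piperidin-3-yl group gives an at least 6.6-fold higher number from compound 2 to compound 4 (0.82 log units; beyond the scatter) and an at least 5.0-fold higher number from compound 1 to compound 4 (0.69 log units; beyond the scatter), so this aromatic carbon of the shared core, where cyclohexylamino and methyl stayed within the scatter of each other, does respond to the group placed on it. The direct step between the two piperidine isomers cannot be read, since compound 3 has no reported result.

On these data alone, it remains open whether piperidin-4-yl on this carbon would sit with compound 1 and compound 2 or with compound 4. As far as these compounds go, it is equally open whether a morpholin-4-yl ring or an open-chain amine such as aminoethyl would keep the number close to that of compound 2.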